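A few compounds are considered here, and "the series" means these few. Any claim that something is new, unique, unknown or untested is made for them only; others in the source may bear on it.

Series notes. In a functional assay on HEK293 cells for agonist activity at Free fatty acid receptor 1 (Homo sapiens), read by fluorescence and calcium flux, with a stated time of 10 min (a higher number here means a larger maximal response, a lower number a smaller maximal response), compound 1 `COCCOc1ccc2c(c1)OC(COc1ccc(CCC(=O)O)c(F)c1)CC2` gives 36%, compound 2 `CC#C[C@@H](CC(=O)O)c1ccc(OC[C@H]2COc3ccc(Cl)cc3O2)cc1` gives 86% and compound 3 `CC#C[C@@H](CC(=O)O)c1ccc(OC[C@H]2COc3ccc(Br)cc3O2)cc1` gives 69%. Compound 3 thus stands second of the three, with compound 2 higher and compound 1 lower, both gaps beyond the scatter. Within the data shown here, the only measured step that bears on the next change is a number 17 percentage points lower from compound 2 to compound 3 (beyond the scatter), which shows that exchanging the group on that aromatic carbon shifts the maximal response by a modest amount. Compound 4 `CC#C[C@@H](CC(=O)O)c1ccc(OC[C@H]2COc3ccc(OC(F)(F)F)cc3O2)cc1` differs from compound 3 as trifluoromethoxy in place of bromo on an aromatic carbon. Among the measured compounds shown here, no measured step covers trifluoromethoxy, so the expectation rests on that single exchange and stays cautious. The expected step is therefore a number 1 percentage points higher from compound 3 to compound 4 (within the scatter). For compound 4 the estimate is 70%, between 50% and 90%.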

Compound 4, largest response reached (Emax), in percent of the reference or control that the assay uses: 73%
For compound 4 the middle estimate is 3 percentage points below the measured one; the range from low to high includes it.
By their numbers in this assay, from the lowest: compound 1; then compounds 3 and 4 (each within the scatter of the next); then compound 2.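

At this aromatic carbon, the larger trifluoromethoxy group, with five heavy atoms and one hydrogen-bond acceptor, can replace the single bromine atom without a measurable change in maximal response (a number 4 percentage points higher from compound 3 to compound 4 (within the scatter)). Against chloro the same group gives a real loss (a number 13 percentage points lower from compound 2 to compound 4 (beyond the scatter)), so in this assay the two larger replacements both leave compound 2 on top. Nothing available explains why chloro gives the larger response. As far as these compounds go, whether fluoro, methyl or an amine on this carbon would equal or pass compound 2 remains open. So does whether the response depends on the group's size at all.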